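Extending the Saturated Chain With a Methoxymethyl Group

The source may hold more compounds than are shown below. What is called first, only, known or untested is meant among the compounds shown, and "the series" means these compounds.

Compound 1, `C/C(=C(/c1ccc(/C=C/C(=O)O)cc1)c1ccc2[nH]ncc2c1)c1ccccc1`: 40 nM
Compound 2, `CCC/C(=C(/c1ccc(/C=C/C(=O)O)cc1)c1ccc2[nH]ncc2c1)c1ccccc1`: 11 nM
Compound 3, `COC/C(=C(/c1ccc(/C=C/C(=O)O)cc1)c1ccc2[nH]ncc2c1)c1ccccc1`: 88 nM

In a functional assay on MCF7 cells (Homo sapiens) for cytotoxicity, read by CellTiter-Glo, with a stated time of 5 days (a higher number here means a weaker inhibitor, a lower number a stronger inhibitor), compound 1 holds the second highest of the three numbers; compound 3 lies nearest to it and compound 2 furthest from it. Compound 4, `COCC/C(=C(/c1ccc(/C=C/C(=O)O)cc1)c1ccc2[nH]ncc2c1)c1ccccc1`, differs from compound 1 by methoxymethyl in place of hydrogen on a saturated chain carbon bound to a double-bonded chain carbon. For the measured compounds named here, two measured steps bear on this change. Ethyl in place of hydrogen gave a 3.6-fold lower number from compound 1 to compound 2 (0.56 log units; beyond the scatter), whereas methoxy in place of hydrogen gave a 2.2-fold higher number from compound 1 to compound 3 (0.34 log units; beyond the scatter). Compound 4 carries both a longer chain and a methoxy, so the two opposing steps are expected to offset one another, and the step of a 1.1-fold lower number from compound 1 to compound 4 (0.06 log units; within the scatter) is expected to stay near or within the scatter. Compound 4 is therefore estimated at 35 nM, with a range from 12 nM to 100 nM.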

Compound 4, half-maximal inhibitory concentration: 63 nM
Beside the measured number, compound 4's estimate is 1.8-fold (0.26 log units) below it, within the range that was stated.
By their numbers in this assay, from the lowest: compound 2; then compounds 1, 4 and 3 (each within the scatter of the next, the first and the last beyond it).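

In this assay, methoxymethyl in place of hydrogen gives a 1.6-fold higher number from compound 1 to compound 4 (0.20 log units; within the scatter), and methoxymethyl in place of methoxy gives a 1.4-fold lower number from compound 3 to compound 4 (0.15 log units; within the scatter), so at this position compound 4 cannot be told apart from either compound 1 or compound 3. Methoxy in place of methyl, two bonds along the chain from a double-bonded chain carbon, gives a 5.7-fold higher number from compound 2 to compound 4 (0.76 log units; beyond the scatter), so the lower number of the all-carbon chain in compound 2 does not carry over to the chain holding oxygen.

Nothing measured here accounts for this difference. As far as these compounds go, whether an amine or a longer carbon chain at this position would behave like compound 2 or like compound 4 remains open.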